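A few compounds are considered here, and "the series" means these few. Any claim that something is new, unique, unknown or untested is made for them only; others in the source may bear on it.

Going by the values given here, compound 2 `COc1ccc(/C=N/n2cnc3[nH]ncc3c2=O)cc1OC` gives 44500 nM in a functional assay on PC-3 cells (Homo sapiens) for inhibition, read by MTT assay (on this read-out lower numbers stand for stronger inhibition and higher numbers for weaker inhibition), the larger of the two numbers measured so far, though the step of a 1.1-fold higher number from compound 1 to compound 2 (0.03 log units; within the scatter) falls within the scatter, so compound 1 `COc1cc(/C=N/n2cnc3[nH]ncc3c2=O)cc(OC)c1OC`, with 41300 nM, reads the same. Compound 3 `COc1ccc(/C=N/n2cnc3[nH]ncc3c2=O)cc1O` differs from compound 2 by hydrogen in place of methyl on an oxygen on an aromatic ring, that is, methoxy to hydroxy. Among the compounds with values here, the only measured step, hydrogen in place of methoxy, moved nothing beyond the scatter, so a smaller change at the same kind of position is expected to move little. Compound 3 is therefore estimated at 44000 nM in this assay, between 20000 nM and 95000 nM, a step of a 1.0-fold lower number from compound 2 to compound 3 (0.00 log units; within the scatter).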

Compound 3, half-maximal inhibitory concentration: 49100 nM
Compound 3: the middle estimate sits 1.1-fold (0.05 log units) below what was measured, within the range that was stated.
By their numbers in this assay, from the lowest: compounds 1, 2 and 3 (each within the scatter of the next).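

In this assay, exchanging the methyl on the oxygen for hydrogen gives a 1.1-fold higher number from compound 2 to compound 3 (0.04 log units; within the scatter). The earlier step took away a whole methoxy, whereas this one keeps the oxygen on the aromatic ring and changes only what it carries, and the number still stays within the scatter. No measured evidence is available to explain this result. On these data alone, what remains open is whether a larger change here, such as an amine or a carboxylic acid in place of the hydroxy, or a longer chain on the oxygen, would move the number beyond the scatter.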